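The source may report more compounds than this note shows. Statements on the series, on what has been measured and on what is new or still open speak of the compounds shown alone.

Compound 1 `COc1cc(-c2cc(-c3cc(C(C)C)c(O)cc3C)[nH]c(=O)c2C#N)ccc1O`: 26%
Compound 2 `COc1ccc(-c2cc(-c3cc(C(C)C)c(O)cc3C)[nH]c(=O)c2C#N)cc1OC`: 25%

In a functional assay for inhibition, tested at 20 ug/mL (on this read-out higher numbers stand for a stronger effect at the one concentration tested and lower numbers for a weaker effect), compound 1 gives 26% and compound 2 gives 25%. For the measured compounds named here, of these two numbers compound 2 stands as the lower, but its nearest neighbour is compound 1, and the single measured step, a number 1 percentage points lower from compound 1 to compound 2 (within the scatter), is within the scatter, so the two compounds are not separated by these data.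

Compound 3 `Cc1cc(O)c(C(C)C)cc1-c1cc(-c2ccccc2[N+](=O)[O-])c(C#N)c(=O)[nH]1` differs from compound 2 by 2-nitrophenyl in place of 3,4-dimethoxyphenyl on an aromatic carbon. Going by the values given here, no measured step exchanges a whole aryl group on this carbon of the shared core. Among the compounds with values here, the only step available concerns a methyl on an oxygen of the group that now leaves, and it was within the scatter, so it shows that a small change on that group left this assay unchanged but gives no guide to a change of this size. With nothing to point in either direction, compound 3 is expected to stay near compound 2, as a step of no change at the digits printed from compound 2 to compound 3 (within the scatter) with no shift beyond the scatter. The estimate for compound 3 is 25%, with a wide range from 8% to 45%.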

Compound 3, a percentage reported as inhibition, at one concentration (the size of the read-out at that concentration, not a potency): 20%
For compound 3 the middle estimate is 5 percentage points above the measured one; the range from low to high includes it.
By their numbers in this assay, from the lowest: compounds 3, 2 and 1 (each within the scatter of the next).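

The new compound widens what is known about this carbon of the shared core, opposite the ring nitrogen and ortho to a cyano group: the earlier pair covered only a methyl on an oxygen of the aryl group, whereas here the whole aryl group is exchanged. In this assay, putting 2-nitrophenyl in place of 3,4-dimethoxyphenyl gives a number 5 percentage points lower from compound 2 to compound 3 (within the scatter), and putting it in place of 4-hydroxy-3-methoxyphenyl gives a number 6 percentage points lower from compound 1 to compound 3 (within the scatter), so this read-out separates none of the three aryl groups, even though the two oxygen substituents have given way to a single nitro group. Nothing available explains this result or links it to any property of these groups.

On these data alone, it remains open whether a group of another kind on this carbon, such as a 4-aminophenyl or a 4-carboxyphenyl ring, or a longer alkyl chain in place of the aryl ring, would move the read-out beyond the scatter. For the compounds shown here, each compound also has only a single reading at one concentration, so how the three compare in potency remains unknown.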